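The source may report more compounds than this note shows. Statements on the series, on what has been measured and on what is new or still open speak of the compounds shown alone.

Measured so far:

compound 1 `O=C(Nc1ccc(Oc2ccnc3[nH]ccc23)cc1)c1nn(-c2ccc(Cl)cc2)ccc1=O` — 19500 nM
compound 2 `O=C(Nc1ccc(Oc2ccnc3[nH]ccc23)c(F)c1)c1nn(-c2ccc(Br)cc2)ccc1=O` — 68000 nM
compound 3 `Cn1ccc2c(Oc3ccc(NC(=O)c4nn(-c5ccc(Cl)cc5)ccc4=O)cc3)ccnc21` — limit only

In a functional assay on HepG2 cells (Homo sapiens) for cytotoxicity, read by MTT assay, with a stated time of 72 h (on this read-out lower numbers stand for stronger inhibition and higher numbers for weaker inhibition), compound 1 gives 19500 nM. Among the compounds with values here, compound 2 gives 68000 nM in this assay; it differs from compound 1 in two places, so no single step is drawn between them. For compound 3 this assay reports only a limit, > 60000 nM. The step of an at least 3.0-fold higher number from compound 1 to compound 3 (0.48 log units; beyond the scatter) therefore ends at the bound given by the limit of > 60000 nM in this assay, at which 1 of the 3 values shown sits, and compound 3 stands at the weak end of the series shown, with no number of its own.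

Compound 4 `Cn1ccc2c(Oc3ccc(NC(=O)c4nn(-c5ccc(Cl)c(F)c5)ccc4=O)cc3)ccnc21` differs from compound 3 by fluoro in place of hydrogen on an aromatic carbon. Within the data shown here, none of the measured steps touches this position on the chlorophenyl ring; the only step drawn, from compound 1 to compound 3, concerns the methyl on the aromatic nitrogen, which compound 4 keeps. Among the measured compounds shown here, with no step bearing on the change, a step of no size beyond the scatter is expected, a step that the limit leaves unreadable from compound 3 to compound 4, and compound 4 is estimated at 70000 nM, within 30000 nM to 150000 nM, most likely again reported only as a limit.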

Compound 4, half-maximal inhibitory concentration: > 60000 nM
Compound 4 ended at the assay's limit; the forecaster's own chance of this, stated with the estimate: 70%; the middle value lies beyond the limit too.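

Compound 3 and compound 4 both end at a limit in this assay, so no step can be read between them: the limit of > 60000 nM in this assay, at which 2 of the 4 values shown sit.

The compounds shown leave open whether 4-chloro-3-fluorophenyl in place of 4-chlorophenyl shifts the read-out at all.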